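The source may hold more compounds than are shown below. What is called first, only, known or untested is meant among the compounds shown, and "the series" means these compounds.

Measured so far in a functional assay on the whole organism (strain Kunming) with Mus musculus as the target, with a stated time of 0.5 h, at a dose of 100 mg/kg by the intraperitoneal route; on this read-out lower numbers stand for a stronger effect and higher numbers for a weaker effect at the one dose given:

compound 1, `COc1cc(OC)c(OC)cc1/C=C/COC(=O)/C=C/c1ccc(OC)c(OC)c1`, gives 100%
compound 2, `COc1cc(OC)c(OC)cc1/C=C/COC(=O)/C=C/c1cc(OC)c(OC)c(OC)c1OC`, gives 100%
compound 3, `COc1cc(OC)c(OC)cc1/C=C/COC(=O)/C=C/c1ccccc1C(F)(F)F`, gives 100%

Compound 3 stands level with both of the other measured compounds at the digits shown. Going by the values given here, the one measured step, no change at the digits printed from compound 1 to compound 3 (within the scatter), stays within the scatter, so exchanging one aryl group on the double-bonded chain carbon for another left the read-out where it was. Among the compounds with values here, compound 2 shows the same value as compound 3, and no step between them is recorded; their two values simply agree. At this dose, then, none of the three measured compounds moves the read-out away from the common level.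

Compound 4, `COc1cccc(/C=C/C(=O)OC/C=C/c2cc(OC)c(OC)cc2OC)c1`, has not yet been tested. It differs from compound 3 in one place: 3-methoxyphenyl in place of 2-(trifluoromethyl)phenyl on a double-bonded chain carbon bound to a double-bonded chain carbon. Within the data shown here, the only measured step that bears on this kind of change is no change at the digits printed from compound 1 to compound 3 (within the scatter), and it was a step of no size beyond the scatter, even though it too exchanged the whole aryl group at the same place. Among the measured compounds shown here, with every measured compound resting at one level, there is no step in the data that points up or down for the new aryl group. Compound 4 is therefore expected to rest at about 100%, with a range from 85% to 100%, meaning an expected step of no change at the digits printed from compound 3 to compound 4 (within the scatter).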

Compound 4, a percentage reported as activity, at one dose (the size of the read-out at that dose, not a potency): 100%
Compound 4: the middle estimate sits on the measured number at the digits printed; the measured number falls inside the stated range.
By their numbers in this assay, from the lowest: compounds 1, 2, 3 and 4 (each within the scatter of the next).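

In this assay, placing 3-methoxyphenyl where 2-(trifluoromethyl)phenyl stood on a double-bonded chain carbon bound to a double-bonded chain carbon gives no change at the digits printed from compound 3 to compound 4 (within the scatter). This is a second whole-group exchange at this position, and here the group that enters has no fluorine and counts one hydrogen-bond acceptor where the group that leaves counts none, yet the two read-outs still agree. The new compound also brings the first comparison of a smaller kind at this aryl group: hydrogen in place of methoxy on an aromatic carbon gives no change at the digits printed from compound 1 to compound 4 (within the scatter), and no measurement available here offers an explanation for the agreement among these compounds.

All four compounds share one value, so this position has not yet yielded any difference that could rank its groups, and a single dose cannot show whether differences would appear at another dose. Still open, going by these compounds, is whether a more different group on this aryl ring, such as an amine or a carboxylic acid, or any change to the shared core away from this position, would bring the read-out away from this common level.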